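A Chloro Substituent Added to an Inactive Series

The compounds below may be only part of what the source reports. "The series", "measured", "known", "first", "only" and "open" are said of these compounds alone.

The three measured compounds share one core and differ only in the terminal part of one side chain. Compound 1 `COC(=O)CC/C(C)=C/Cc1c(OC)c(C)c2c(c1OCC#CCN1CCN(C(c3ccccc3)c3ccccc3)CC1)C(=O)OC2` is the parent of the pair followed here. In a functional assay on FaDu cells (Homo sapiens) for inhibition, read by sulforhodamine B assay (a higher number here means a weaker inhibitor, a lower number a stronger inhibitor), compound 1 gives > 50000 nM, which is a limit of the assay rather than a number. Compound 2 `COC(=O)CC/C(C)=C/Cc1c(OC)c(C)c2c(c1OCC#CCN1CCN(C(=O)C3COc4ccccc4O3)CC1)C(=O)OC2` is a second member; in this assay compound 2 gives > 50000 nM, again a limit. Compound 3 `COC(=O)CC/C(C)=C/Cc1c(OC)c(C)c2c(c1OCC#CCN1CCC(Cc3ccccc3)CC1)C(=O)OC2` is the third; in this assay compound 3 gives > 50000 nM, once more a limit. Within the data shown here, compound 1 therefore stands exactly where every value stands, namely (the limit of > 50000 nM in this assay, at which 3 of the 3 values shown sit), and no step between measured compounds can be sized or ordered.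

Compound 4 `COC(=O)CC/C(C)=C/Cc1c(OC)c(C)c2c(c1OCC#CCN1CCN(C(c3ccccc3)c3ccc(Cl)cc3)CC1)C(=O)OC2` is the next member: chloro in place of hydrogen on an aromatic carbon. Read one bond further out, the change is phenyl to 4-chlorophenyl. Because the limit of > 50000 nM in this assay, at which 3 of the 3 values shown sit, holds for every value shown, the step that the limit leaves unreadable from compound 1 to compound 4 is expected to be none beyond the scatter, with no direction that the data could support. For compound 4 the estimate in this assay is 70000 nM, in a range from 25000 nM to 250000 nM, and the result is expected most likely to be reported again as a limit.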

Compound 4, half-maximal inhibitory concentration: > 50000 nM
Compound 4: a limit, no number; the forecaster's own chance of this, stated with the estimate: 85%; the middle value is on the limit's open side.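

In this assay compound 4 gives > 50000 nM, which is a limit and not a number. No step can be read between compound 1 and compound 4, since both stand at the same limit: the limit of > 50000 nM in this assay, at which 4 of the 4 values shown sit. The compounds shown leave open which terminal group on the side chain, if any, would give a measurable value in this assay.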